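The compounds below may be only part of what the source reports. "The series", "measured", "known", "first", "only" and "open" are said of these compounds alone.

Measured so far in an ADME assay on microsomes from liver (Homo sapiens) for metabolic stability, using NADPH, with a stated time of 40 min, tested at 2 uM (a higher number here means that the compound lasts longer, a lower number that the compound disappears faster), as half-life:
compound 1 `Cc1cccc2c(-c3ccc4cccc(Br)c4n3)c[nH]c12` at 2.4 h
compound 2 `Fc1ccc2c(-c3ccc4ccccc4n3)c[nH]c2c1Cl` at 0.183 h

Compound 1 holds the higher of the two numbers at 2.4 h and compound 2 the lower at 0.183 h with the gap beyond the usual scatter. Among the compounds with values here, no two measured compounds differ in one place only, so the series gives no direct measure of a single change.

Next is compound 3 `Cc1cccc2c(-c3ccc4cccc(Cl)c4n3)c[nH]c12` which has not yet been measured. Its difference from compound 1 is chloro in place of bromo on an aromatic carbon with chloro in place of bromo on an aromatic carbon and the rest of the structure unchanged. Within the data shown here, with no measured step to draw on, no change beyond the scatter is expected in this assay and neither direction is favoured. The estimate therefore stays close to compound 1 at 2.4 h as its only anchor. The estimated 1.1-fold lower number from compound 1 to compound 3 (0.04 log units; within the scatter) is expected to remain within the scatter. For compound 3 the expected half-life is 2.2 h with an estimated range from 1 h to 4.5 h for the coming measurement.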

Compound 3, half-life: 1.75 h
Beside the measured number, compound 3's estimate is 1.3-fold (0.10 log units) above it, and the stated range covers the measured number.
By their numbers in this assay, from the lowest: compound 2; then compounds 3 and 1 (each within the scatter of the next).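

In this assay, within the data shown here, chloro in place of bromo on an aromatic carbon, ortho to a fused ring and meta to a fused ring, gives a 1.4-fold lower number from compound 1 to compound 3 (0.14 log units; within the scatter) and provides the first step between compounds that differ in one place. At this position on the shared core, the read-out therefore does not separate bromo from chloro, and the half-life of this pair tolerates the exchange of one halogen for the other within the usual scatter; this rests on a single step and applies to this position and this pair alone. No measured evidence is available to explain why the two compounds read alike.

The compounds shown leave open whether a group of another kind at this position, such as an amine, a carboxylic acid or a longer chain, would stay within the scatter of these two halogens or move the half-life beyond it. Also open is what the methyl group elsewhere on the shared core contributes, as no pair shown isolates it.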